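Sulfonyl substituent swap in a urea activator series

The source may hold more compounds than are shown below. What is called first, only, known or untested is meant among the compounds shown, and "the series" means these compounds.

Measured compounds, with their values in an assay on isolated protein for activation of Nicotinamide phosphoribosyltransferase (Homo sapiens); on this read-out higher numbers stand for an effect only at larger amounts of compound and lower numbers for an effect already at smaller amounts:
compound 2, `O=C(NCc1ccncc1)Nc1ccc(S(=O)(=O)c2ccccc2Cl)cc1`: 79 nM
compound 3, `O=C(NCc1cnco1)Nc1ccc(S(=O)(=O)c2ccccc2)cc1`: 77 nM
compound 1, `CCOC(=O)c1ccc(NC(=O)NCc2cocn2)cc1`: 27600 nM

Compound 2 holds the second highest of the three numbers in this assay. It sits next to compound 3, whose value lies within the usual scatter of the value of compound 2, so no order between the two can be read. The furthest of the three is compound 1, whose number is higher by a margin well beyond the scatter.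

Compound 4, `CN(C1CCCC1)S(=O)(=O)c1ccc(NC(=O)NCc2ccncc2)cc1`, has not been measured. It differs from compound 2 in a single place: cyclopentyl(methyl)amino in place of 2-chlorophenyl on a sulfonyl sulfur. Among the measured compounds shown here, no measured pair in this set changes the group on the sulfonyl sulfur, so the size of the step has no direct precedent. Both measured compounds with an aromatic group on that sulfur, compound 2 and compound 3, give low numbers; for compound 4 a moderate rise is expected, as the step of a 3.8-fold higher number from compound 2 to compound 4 (0.58 log units; beyond the scatter) states. In this assay compound 4 is therefore estimated at 300 nM, with a plausible range from 80 nM to 1500 nM.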

Compound 4, half-maximal effective concentration: 123 nM
Estimate against measurement, compound 4: 2.4-fold (0.39 log units) above; measured number inside the range.
By their numbers in this assay, from the lowest: compounds 3, 2 and 4 (each within the scatter of the next); then compound 1.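

In this assay, cyclopentyl(methyl)amino in place of 2-chlorophenyl on a sulfonyl sulfur gives a 1.6-fold higher number from compound 2 to compound 4 (0.19 log units; within the scatter), so no change can be read from this exchange. Compound 2 and compound 3 carried only aromatic groups on that sulfur, whereas compound 4 shows that a non-aromatic ring attached through nitrogen can stand there with the number still within the scatter of compound 2. Nothing available accounts for how little the number moves with this exchange.

Still open, going by these compounds, is whether a smaller amine such as dimethylamino, or a more open chain such as diethylamino, would keep the number on this sulfur. On these data alone, it is also open whether the same exchange would hold with the other urea substituent of compound 3.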